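The compounds below may be only part of what the source reports. "The series", "measured", "known", "first", "only" and "open" are said of these compounds alone.

Compound 1, `Cn1nc(-c2cccnc2)c2ccccc2c1=O`, gives 11500 nM in a functional assay (trachea) with Cavia porcellus as the target; a lower number here means a stronger inhibitor, a higher number a weaker inhibitor.
Compound 2, `CCCn1nc(-c2cccnc2)c2ccccc2c1=O`, gives 3160 nM in this assay.
Compound 3, `CCCCn1nc(-c2cccnc2)c2ccccc2c1=O`, gives 2290 nM in this assay.

Compound 2 stands second highest among these three numbers in this assay: its nearest neighbour is compound 3, with a step of a 1.4-fold lower number from compound 2 to compound 3 (0.14 log units; within the scatter), and its furthest is compound 1, from which the step of a 3.6-fold lower number from compound 1 to compound 2 (0.56 log units; beyond the scatter) leads down to it. The unmeasured compound 4, `O=c1c2ccccc2c(-c2cccnc2)nn1CC1CCCCC1`, differs from compound 2 by cyclohexyl in place of ethyl on a saturated chain carbon bound to an aromatic nitrogen.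

Among the compounds with values here, two measured steps bear on this change. Both enlarge the chain on the saturated carbon bound to the aromatic nitrogen: a 3.6-fold lower number from compound 1 to compound 2 (0.56 log units; beyond the scatter) and a 5.0-fold lower number from compound 1 to compound 3 (0.70 log units; beyond the scatter) were modest but beyond the scatter, while the further lengthening a 1.4-fold lower number from compound 2 to compound 3 (0.14 log units; within the scatter) stayed within it. The move from ethyl to cyclohexyl is a larger enlargement than either, so a modest further lowering is expected in this assay, though it may also prove no larger than the scatter, as the step from compound 2 to compound 3 did.

For compound 4 the expected step is a 2.1-fold lower number from compound 2 to compound 4 (0.32 log units; beyond the scatter). Compound 4 is therefore estimated at 1500 nM, with a range from 500 nM to 4500 nM.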

Compound 4, half-maximal inhibitory concentration: 209 nM
Compound 4: the middle estimate sits 7.2-fold (0.86 log units) above what was measured, outside the stated range (below it).
By their numbers in this assay, from the lowest: compound 4; then compounds 3 and 2 (each within the scatter of the next); then compound 1.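

The cyclohexyl group changes the picture at the saturated chain carbon bound to the aromatic nitrogen: the earlier lengthening had levelled off, with a 1.4-fold lower number from compound 2 to compound 3 (0.14 log units; within the scatter), yet replacing ethyl with cyclohexyl gives a 15-fold lower number from compound 2 to compound 4 (1.18 log units; beyond the scatter), and replacing propyl with cyclohexyl gives an 11-fold lower number from compound 3 to compound 4 (1.04 log units; beyond the scatter). Both steps are large, and in this assay the full change from the hydrogen at this place gives a 55-fold lower number from compound 1 to compound 4 (1.74 log units; beyond the scatter), making compound 4 the strongest inhibitor of the four, with its steps to all the others beyond the scatter. This position therefore tolerates a much larger carbon group than the propyl of compound 3 and can gain substantially from it, although no measured property among these compounds accounts for the gain.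

From the compounds shown here alone, the four compounds do not separate the effect of the six-membered ring from that of the added carbons, so it remains open whether an open hexyl chain, a smaller cyclopentyl ring or an aromatic phenyl ring would match cyclohexyl here. Going by these compounds, it is equally open how an amine or a carboxylic acid placed on the cyclohexyl ring would read in this assay.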